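Adding a chloro to compound 1: an expectation

This account rests on a few compounds, and the source may have more. Where it says the series, first, only, none or still open, it means among the compounds named here.

Compound 1 `CCN1C(=O)CC[C@H]1C(=O)NCc1ccccc1Cl` stands level with compound 2 at the digits shown. In an assay on isolated protein for inhibition of P2X purinoceptor 7 (Homo sapiens) (a lower number here means a stronger inhibitor, a higher number a weaker inhibitor), compound 1 gives 631 nM. Compound 2 `CCN1C(=O)CC[C@H]1C(=O)NCc1ccccc1C(F)(F)F` carries trifluoromethyl in place of chloro on an aromatic carbon, and in this assay compound 2 gives 631 nM; the step is no change at the digits printed from compound 1 to compound 2 (within the scatter). Compound 3 `CCN1C(=O)CC[C@H]1C(=O)NCc1ccccc1OC` carries methoxy in place of chloro on an aromatic carbon, and in this assay compound 3 is recorded only as a limit, < 1000 nM. Because of the limit of < 1000 nM in this assay, at which 1 of the 3 values shown sits, the steps a step that the limit leaves unreadable from compound 1 to compound 3 and a step that the limit leaves unreadable from compound 2 to compound 3 cannot be read in size.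

Compound 4 `CCN1C(=O)CC[C@H]1C(=O)NCc1ccc(Cl)cc1Cl` differs from compound 1 by chloro in place of hydrogen on an aromatic carbon. Within the data shown here, no measured step adds a group to an unsubstituted aromatic carbon; the only readable step, no change at the digits printed from compound 1 to compound 2 (within the scatter), swaps one group for another and stays within the scatter. A change of modest size is therefore expected in this assay, with the direction uncertain. Compound 4 is estimated at 400 nM, between 150 nM and 1500 nM, which means an expected step of a 1.6-fold lower number from compound 1 to compound 4 (0.20 log units; within the scatter).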

Compound 4, half-maximal inhibitory concentration: 6.31 nM
For compound 4 the middle estimate is 63-fold (1.80 log units) above the measured one; measured number outside the range, below it.
By their numbers in this assay, from the lowest: compound 4; then compounds 1 and 2 (each within the scatter of the next).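

Placing a chloro on the aromatic carbon para to a large group and meta to the existing chloro group gives a 100-fold lower number from compound 1 to compound 4 (2.00 log units; beyond the scatter) in this assay. Among these compounds, the earlier compounds differ only in the group already on the ring, and their one readable swap gives no change at the digits printed from compound 1 to compound 2 (within the scatter), so they gave no sign of a step of this size. The carbon that bears hydrogen in compounds 1, 2 and 3 is thus a place where a single added heavy atom moves the number well beyond the scatter, at least with a chloro already on the ring.

Compound 3 is recorded only as a limit, < 1000 nM, and the steps that involve it cannot be read in size: the limit of < 1000 nM in this assay, at which 1 of the 4 values shown sits. Still open, on these data alone, is whether fluoro, a methyl, an amine or a carboxylic acid at this place would give a similar step, and whether the added chloro would do the same with trifluoromethyl or methoxy as the other ring group.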